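The compounds below may be only part of what the source reports. "The series", "measured", "known", "first", "only" and "open" are said of these compounds alone.

Series notes, cytotoxicity on the shared core.

Compound 1 `CCOCn1c(Cc2cc(F)cc(F)c2)c(I)c(=O)[nH]c1=O` is the reference point; in an ADME assay on MT4 cells (Homo sapiens) for cytotoxicity, read by XTT assay, with a stated time of 3 days (a higher number here means that more compound is tolerated, a lower number that less compound is tolerated), compound 1 gives 300000 nM. Compound 2 `O=c1[nH]c(=O)n(COCc2ccccc2)c(Cc2cc(F)cc(F)c2)c1I` carries the change phenyl in place of methyl on a saturated chain carbon bound to an oxygen on a saturated carbon relative to compound 1, and in this assay compound 2 gives 121000 nM. The step this made is a 2.5-fold lower number from compound 1 to compound 2 (0.39 log units; beyond the scatter).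

Compound 3 `CCOCn1c(Cc2ccccc2)c(N(C)C)c(=O)[nH]c1=O` has a different core; in this assay compound 3 gives 166000 nM. The difference between the core of compound 3 and the core of compound 1 is not broken down here, so only the two values are compared: they lie within the scatter of one another.

Compound 4 `CN(C)c1c(Cc2ccccc2)n(COCc2ccccc2)c(=O)[nH]c1=O` is not yet measured. Relative to compound 3 it carries the change (phenyl in place of methyl on a saturated chain carbon bound to an oxygen on a saturated carbon), at the same place as before, so it is the same change as the one from compound 1 to compound 2, which occurs twice among these compounds. The expected step is a 2.4-fold lower number from compound 3 to compound 4 (0.38 log units; beyond the scatter), set beside the earlier one and resting on the step of a 2.5-fold lower number from compound 1 to compound 2 (0.39 log units; beyond the scatter), with the core of compound 3 assumed not to alter its size. The estimate for compound 4 in this assay is therefore 70000 nM, expected to fall between 30000 nM and 170000 nM.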

Compound 4, half-maximal cytotoxic concentration: 91800 nM
Compound 4: the middle estimate sits 1.3-fold (0.12 log units) below what was measured, within the range that was stated.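

In this assay the change from ethoxymethyl to (benzyloxy)methyl gives a 1.8-fold lower number from compound 3 to compound 4 (0.26 log units; within the scatter) and so cannot, taken alone, be told apart from repeat measurement. Set beside the earlier step, the change reads alike on the two cores: the same change on two cores in this assay, a 2.5-fold lower number (0.39 log units; beyond the scatter) from compound 1 to compound 2 and a 1.8-fold lower number (0.26 log units; within the scatter) from compound 3 to compound 4, 1.4-fold (0.14 log units) apart, within the scatter of two such steps.

This shows that, as far as these two pairs can tell, the size of the step carries from the core of compound 1 to the core of compound 3 without a detectable difference, but it does not show that the change would behave the same way on any other core or in any other assay, nor does it explain why the step has this size.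

Still open, from the compounds shown here alone, is whether a longer chain, or an amine or a carboxylic acid at the end of the chain, would give a step of similar size in place of phenyl on that saturated chain carbon. Going by these compounds alone, also open is whether the two cores would stay alike with such groups, since only one change has been compared across them here.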